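This account rests on a few compounds, and the source may have more. Where it says the series, first, only, none or still open, it means among the compounds named here.

In a physicochemical assay for lipophilicity, read by HPLC, measured as chromatographic lipophilicity, at pH 7.4 (on this read-out higher numbers stand for higher lipophilicity and lower numbers for lower lipophilicity), compound 1 `CC(C)(C)C(=O)n1nccc1-c1ccccc1` reads 8.3, while compound 2 `O=C(c1cccnc1)N1CCC(C(=O)N2N=CCC2c2ccccc2)CC1` reads 2.6. Compound 2 is therefore the lower of the two measured compounds, and its gap to compound 1 lies well beyond the scatter of repeated measurements. Compound 3 `CN1CCC(C(=O)N2N=CCC2c2ccccc2)CC1` has not yet been measured. It differs from compound 2 in one place: methyl in place of (pyridin-3-yl)carbonyl on an amine nitrogen in a ring, with methyl in place of (pyridin-3-yl)carbonyl on an amine nitrogen in a ring. For the measured compounds named here, no measured pair shows this change, so the expectation rests on the structural change alone and remains broad. A moderate fall beyond the scatter is expected in this assay, with an estimated step of a number 1.00 log units lower from compound 2 to compound 3 (beyond the scatter). For compound 3 the estimated value is 1.6, with an expected range of 0.4 to 2.9.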

Compound 3, distribution coefficient: 1.1
Compound 3: middle estimate off by 0.50 log units, on the high side, and the stated range covers the measured number.
By their numbers in this assay, from the lowest: compound 3; then compound 2; then compound 1.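

In this assay, for the compounds shown here, the change at this amine nitrogen in a ring gives a number 1.50 log units lower from compound 2 to compound 3 (beyond the scatter), the first single-place step, and it shows that the read-out responds strongly to the group on this nitrogen. In that step, a group of 8 heavy atoms with a six-membered aromatic ring with 1 hetero atom and 2 hydrogen-bond acceptors gives way to methyl, with 1 heavy atom and neither feature. No measurement here separates the contributions of those parts to the step or explains its size.

As far as these compounds go, whether an acetyl or benzoyl group on this nitrogen would read nearer compound 2 or compound 3 remains open. Also open, from the compounds shown here alone, is whether an ethyl group or a longer alkyl chain would raise the number relative to compound 3 .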